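Halogen swap on the benzoic acid arm of the series

A few compounds are considered here, and "the series" means these few. Any claim that something is new, unique, unknown or untested is made for them only; others in the source may bear on it.

Compound 1 `COc1ccc(C(=O)O)cc1O[C@@H](C)COc1ccc(C(=O)CC(C)(C)C)c(O)c1C` gives 137 nM in an assay for positive allosteric modulation of metabotropic glutamate receptor 2 (Rattus norvegicus) (a higher number here means that more compound is needed for the effect, a lower number that less compound is needed), and compound 2 `COc1cc(C(=O)O)ccc1OC[C@H](C)COc1ccc(C(=O)CC(C)(C)C)c(O)c1C` gives 28 nM. Compound 3 `Cc1c(OC[C@@H](C)COc2ccc(C(=O)O)cc2F)ccc(C(=O)CC(C)(C)C)c1O` gives 222 nM; this is the largest of the three numbers, but compound 1 sits within the usual scatter of it, so the two are not separated, while compound 2 is beyond it. Among the measured compounds shown here, the one measured step onto this ring is a 7.9-fold higher number from compound 2 to compound 3 (0.90 log units; beyond the scatter).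

Compound 4 `Cc1c(OC[C@@H](C)COc2ccc(C(=O)O)c(Cl)c2)ccc(C(=O)CC(C)(C)C)c1O` differs from compound 3 by 4-carboxy-3-chlorophenyl in place of 4-carboxy-2-fluorophenyl on an oxygen on a saturated carbon. For the measured compounds named here, no measured step exchanges one halogen for another or moves a substituent around this ring; the step from compound 2 to compound 3 concerns a different exchange and gives only a loose sense of how sensitive this ring is. Going by the values given here, with no direct precedent, no step beyond the scatter is expected in either direction. Compound 4 is therefore estimated at 200 nM, within 70 nM to 600 nM. This estimate means an expected step of a 1.1-fold lower number from compound 3 to compound 4 (0.05 log units; within the scatter), inside the scatter.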

Compound 4, half-maximal effective concentration: 50 nM
Compound 4: the middle estimate sits 4.0-fold (0.60 log units) above what was measured; measured number below the stated range.
By their numbers in this assay, from the lowest: compounds 2 and 4 (each within the scatter of the next); then compounds 1 and 3 (each within the scatter of the next).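

In this assay, the aryl group on the oxygen responds strongly to this exchange: 4-carboxy-3-chlorophenyl in place of 4-carboxy-2-fluorophenyl gives a 4.4-fold lower number from compound 3 to compound 4 (0.65 log units; beyond the scatter). The chlorinated arm also restores a number close to that of the methoxy arm, as compound 2 gives 28 nM and compound 4 gives 50 nM, two values within the scatter of each other. The exchange alters the halogen and its ring number together, and no supporting data explain the result.

From the compounds shown here alone, whether the halogen or its ring number carries the step stays open; 4-carboxy-3-fluorophenyl and 4-carboxy-2-chlorophenyl would separate the two. Also open, going by these compounds, is how a bromine, a methyl or a nitrile would read in place of the chlorine in 4-carboxy-3-chlorophenyl.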